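The source may report more compounds than this note shows. Statements on the series, on what has been measured and on what is new or still open speak of the compounds shown alone.

Measured compounds in a functional assay on HepG2 cells (Homo sapiens) for inhibition, read by MTT assay, with a stated time of 72 h; a higher number here means a weaker inhibitor, a lower number a stronger inhibitor:
Compound 1 `CN(C(=O)NC(=O)c1ccc(Cl)cc1Cl)c1nc(C(F)(F)F)c(C(=O)N/N=C/c2ccccc2C(F)(F)F)s1` gives 10.7 ug/mL.
Compound 2 `CN(C(=O)NC(=O)c1ccccc1F)c1nc(C(F)(F)F)c(C(=O)N/N=C/c2ccccc2C(F)(F)F)s1` gives 5.39 ug/mL.
Compound 3 `CN(C(=O)NC(=O)c1c(F)cccc1F)c1nc(C(F)(F)F)c(C(=O)N/N=C/c2ccccc2C(F)(F)F)s1` gives 26.1 ug/mL.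

Compound 3 gives the highest number of the three, as shown by a 2.4-fold higher number from compound 1 to compound 3 (0.39 log units; beyond the scatter) and by a 4.8-fold higher number from compound 2 to compound 3 (0.69 log units; beyond the scatter), both beyond the scatter. Compound 4 `CN(C(=O)NC(=O)c1cccc([N+](=O)[O-])c1)c1nc(C(F)(F)F)c(C(=O)N/N=C/c2ccccc2C(F)(F)F)s1` differs from compound 3 by 3-nitrophenyl in place of 2,6-difluorophenyl on a carbonyl carbon. The measured steps at this carbonyl-attached aryl group moved the number only modestly, and none of them introduces a nitro group, so the direction of the change is uncertain. For compound 4 a step of a 2.0-fold lower number from compound 3 to compound 4 (0.30 log units; within the scatter) is expected, of similar size to the measured ones and most likely back toward the range of compound 1 and compound 2. The estimate for compound 4 in this assay is 13 ug/mL, within 4.5 ug/mL to 38 ug/mL.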

Compound 4, half-maximal inhibitory concentration: 4.8 ug/mL
Compound 4: the middle estimate sits 2.7-fold (0.43 log units) above what was measured, within the range that was stated.
By their numbers in this assay, from the lowest: compounds 4, 2 and 1 (each within the scatter of the next, the first and the last beyond it); then compound 3.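

In this assay, within the data shown here, a nitro group is accepted on the aryl group at this carbonyl carbon, and 3-nitrophenyl in place of 2,6-difluorophenyl gives the largest step so far (a 5.4-fold lower number from compound 3 to compound 4 (0.74 log units; beyond the scatter)). Against 2,4-dichlorophenyl the change also gives a lower number (a 2.2-fold lower number from compound 1 to compound 4 (0.35 log units; beyond the scatter)), while against 2-fluorophenyl it separates nothing (a 1.1-fold lower number from compound 2 to compound 4 (0.05 log units; within the scatter)). No evidence on hand accounts for these steps.

On these data alone, whether the nitro group itself matters stays open, since 3-nitrophenyl and 2-fluorophenyl cannot be told apart here. An amine or a carboxylic acid in place of the nitro group would test this.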